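Aryl swap on the allyl-bearing core of compound 1

The source may report more compounds than this note shows. Statements on the series, on what has been measured and on what is new or still open speak of the compounds shown alone.

Two compounds of this series have a number in a functional assay on A549 cells (Homo sapiens) for cytotoxicity, read by CCK-8 assay, with a stated time of 72 h (on this read-out lower numbers stand for stronger inhibition and higher numbers for weaker inhibition), so far. Within the data shown here, compound 1 `C=CCn1c(=O)/c(=C\c2cc(F)ccc2C)[nH]c(=O)/c1=C\c1ccccc1OC` gives 4900 nM in this assay, the higher of the two numbers known. Among the measured compounds shown here, compound 2 `COc1ccccc1/C=c1\c(=O)[nH]/c(=C/c2ccccc2Cl)c(=O)n1C` gives 300 nM in this assay, a considerably lower number; compound 2 differs from compound 1 in more than one place, so no single step connects the pair, and only the two values themselves are known.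

Compound 3 `C=CCn1c(=O)/c(=C\c2cccc(Br)c2)[nH]c(=O)/c1=C\c1ccccc1OC` has not yet been measured in this assay. It keeps the core and the allyl group of compound 1 and differs from it in a single place: 3-bromophenyl in place of 5-fluoro-2-methylphenyl on a double-bonded chain carbon bound to an aromatic carbon. For the measured compounds named here, no measured pair isolates a change of this kind, so the size of the step is open. The lower number for compound 2, which carries a halogen-bearing phenyl group without the methyl, gives mild grounds to expect a move toward a lower number for compound 3, of a size near the edge of the scatter rather than clearly beyond it.

Compound 3 is expected to give about 2500 nM in this assay, within a range from 800 nM to 8000 nM. The expected step is a 2.0-fold lower number from compound 1 to compound 3 (0.29 log units; within the scatter).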

Compound 3, half-maximal inhibitory concentration: 5400 nM
The estimate for compound 3 lay 2.2-fold (0.33 log units) below the measured number; the measured number falls inside the stated range.
By their numbers in this assay, from the lowest: compound 2; then compounds 1 and 3 (each within the scatter of the next).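

In this assay, the series now has its first single-place step: exchanging 5-fluoro-2-methylphenyl for 3-bromophenyl on a double-bonded chain carbon bound to an aromatic carbon gives a 1.1-fold higher number from compound 1 to compound 3 (0.04 log units; within the scatter), with the allyl group and the shared core held constant. On this core, the read-out therefore does not separate these two aryl groups, even though the exchange removes the methyl and the fluorine and brings in the bromine. As this is a single combined exchange, it cannot show what each of those substituents contributes alone, and no measurement in hand accounts for the size of the step.

Whether this place tolerates other kinds of group remains open, since an amine or a carboxylic acid on the phenyl ring would test it beyond the halogen-bearing and methyl-bearing groups shown. Among these compounds, compound 2 gives 300 nM, but no single step links it to compound 1, so that number cannot yet be assigned to the aryl group, the group on the ring nitrogen or any other one place.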